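The compounds below may be only part of what the source reports. "The series", "measured", "known", "first", "only" and "open" are said of these compounds alone.

Working notes on the series: in a functional assay on MDA-MB-231 cells (Homo sapiens) for inhibition, read by MTT assay, with a stated time of 72 h (on this read-out lower numbers stand for stronger inhibition and higher numbers for weaker inhibition), compound 1 `COc1ccccc1-c1csc2cnc(Nc3ccc(C(=O)NC4CCNCC4)c(C)c3)nc12` gives 240 nM and compound 2 `CNC(=O)c1ccc(Nc2ncc3scc(-c4ccccc4OC)c3n2)cc1` gives 2120 nM, the higher of the two numbers and beyond the scatter of compound 1. Compound 3 `COc1ccccc1-c1csc2cnc(Nc3ccc(C(=O)NC4CCNCC4)cc3)nc12` remains unmeasured. It departs from compound 2 by piperidin-4-yl in place of methyl on an amide-type nitrogen. For the measured compounds named here, no measured pair isolates this change, but compound 1 also carries the (piperidin-4-yl)carbamoyl group and stands at 240 nM, so a lower number beyond the scatter is expected in this assay. The expected size is a 6.1-fold lower number from compound 2 to compound 3 (0.78 log units; beyond the scatter). For compound 3 the estimated value is 350 nM, with an expected range of 130 nM to 900 nM.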

Compound 3, half-maximal inhibitory concentration: 110 nM
The estimate for compound 3 lay 3.2-fold (0.50 log units) above the measured number, and the stated range ends above it.
By their numbers in this assay, from the lowest: compound 3; then compound 1; then compound 2.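

In this assay, piperidin-4-yl in place of methyl on the amide-type nitrogen now has a direct pair, with a 19-fold lower number from compound 2 to compound 3 (1.28 log units; beyond the scatter), so the change alone accounts for a large step. Hydrogen in place of methyl on the aromatic carbon gives a 2.2-fold lower number from compound 1 to compound 3 (0.34 log units; beyond the scatter), a modest step, so that methyl is not required for this read-out. Nothing measured here explains either step. From the compounds shown here alone, whether the large step follows the ring or its nitrogen stays open; cyclohexyl or a 2-aminoethyl chain on that amide-type nitrogen would separate the two. Going by these compounds, how chloro on that aromatic carbon would compare also stays open.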